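Bicyclooctane triazole series: sulfonamide to butyl at chain terminus

The source may hold more compounds than are shown below. What is called first, only, known or untested is meant among the compounds shown, and "the series" means these compounds.

Two members of the series carry a number in a functional assay on the whole organism (strain ICR) for inhibition, with Mus musculus as the target, with a stated time of 4 h, at a dose of 10 mg/kg by the oral route; on this read-out lower numbers stand for less inhibition and higher numbers for more inhibition at the one dose given (going by the name of the read-out). Compound 1 `CCS(=O)(=O)CCC12CCC(c3nnc(-c4ccccc4C)n3C)(CC1)CC2` gives 86% in this assay. Compound 2 `Cn1c(-c2ccccc2C(F)(F)F)nnc1C12CCC(CNS(C)(=O)=O)(CC1)CC2` gives 73% in this assay, the lower of the two numbers, and the gap to compound 1 lies beyond the scatter; compounds 1 and 2 differ at more than one place, so their two values are taken only as they stand.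

Compound 3 `CCCCCC12CCC(c3nnc(-c4ccccc4C(F)(F)F)n3C)(CC1)CC2` is the next member. Its difference from compound 2 is butyl in place of methanesulfonamido on a saturated chain carbon bound to a saturated ring carbon.

Among the measured compounds shown here, no measured pair isolates this change, so no counted step guides it. Without such a step, compound 3 is expected to sit close to compound 2, with a step in this assay of a number 2 percentage points higher from compound 2 to compound 3 (within the scatter), which is not expected to reach beyond the scatter in either direction. Compound 3 is therefore estimated at 75% in this assay, within a range from 50% to 92%.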

Compound 3, a percentage reported as inhibition, in the whole organism at one dose (the size of the read-out at that dose, not a potency): 98%
The estimate for compound 3 lay 23 percentage points below the measured number; measured number above the stated range.
By their numbers in this assay, from the lowest: compound 2; then compound 1; then compound 3.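

Notes on the chain on the saturated ring carbon: in this assay, this place responds to the change, with butyl in place of methanesulfonamido giving a step of a number 25 percentage points higher from compound 2 to compound 3 (beyond the scatter). The methanesulfonamido group is therefore not required for a high number at this dose, and a purely carbon chain with no hydrogen-bond donors or acceptors is sufficient in this pair. Nothing at hand accounts for the size of the step.

This single pair does not separate the loss of the methanesulfonamido group from the gain of the butyl group, and it does not show how the number depends on chain length. A longer chain such as heptyl, or an amine or a carboxylic acid at the chain end, would test how far the result extends.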